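Acetyl to ethyl on the side chain

The source may report more compounds than this note shows. Statements on the series, on what has been measured and on what is new or still open speak of the compounds shown alone.

Measured so far in a functional assay on NCI-H460 cells (Homo sapiens) for cytotoxicity, read by MTT assay; a higher number here means a weaker inhibitor, a lower number a stronger inhibitor
compound 1 `COc1cc(CCCCC(C)(C)O)oc(=O)c1C` | > 200000 nM
compound 2 `CC(=O)C(C)CCCCc1cc(O)c(C)c(=O)o1` | > 200000 nM

Compound 2 stands at > 200000 nM as a limit of the assay, not a number. Compound 1 reads > 200000 nM as a limit too. Both measured compounds share one reading (the limit of > 200000 nM in this assay, at which 2 of the 2 values shown sit) and neither gives a number.

Within the data shown here, compound 3 `CCC(C)CCCCc1cc(O)c(C)c(=O)o1` carries ethyl in place of acetyl on a saturated chain carbon bound to two saturated chain carbons and has no reading yet in this assay so far.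

Among the measured compounds shown here, no step between measured compounds is available as a guide, so the expectation is weak. Starting from compound 2 at > 200000 nM as a limit, the expected outcome is no step beyond the scatter, with a small move toward a stronger inhibitor as the only possible direction. The expected change is a number no higher from compound 2 to compound 3 (the limit leaves the size open) as a working figure. For compound 3 the estimated value is 200000 nM within an expected range of 80000 nM to 300000 nM as a working figure.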

Compound 3, half-maximal inhibitory concentration: > 200000 nM
Compound 3: only a limit was reported (the forecaster's own chance of this, stated with the estimate: 70%); the middle value lies on the limit itself.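

In this assay, compound 2 and compound 3 give no readable step: both readings are limits of the assay, not numbers. The compounds shown leave open whether ethyl in place of acetyl on a saturated chain carbon bound to two saturated chain carbons changes inhibition at all, and what would bring a reading inside the assay's range.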